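Para-halophenyl thiazole hydrazones: chloro to bromo step

The source may report more compounds than this note shows. Statements on the series, on what has been measured and on what is new or still open speak of the compounds shown alone.

Measured so far:
compound 1, `Fc1ccc(-c2csc(N/N=C/c3ccc(-n4cncn4)cc3)n2)cc1`: 35.9%
compound 2, `Clc1ccc(-c2csc(N/N=C/c3ccc(-n4cncn4)cc3)n2)cc1`: 28.4%

Working notes on the series. In an ADME assay on THP-1 cells (Homo sapiens) for cytotoxicity, read by MTT assay, tested at 50 ug/mL (on this read-out higher numbers stand for more inhibition at the one concentration tested (going by the name of the read-out) and lower numbers for less inhibition), compound 1 gives 35.9% and compound 2 gives 28.4%. Within the data shown here, compound 2 holds the lower of the two numbers measured, but the only recorded step, a number 7.5 percentage points lower from compound 1 to compound 2 (within the scatter), is within the scatter, so the two compounds cannot be ordered on these data.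

Compound 3, `Brc1ccc(-c2csc(N/N=C/c3ccc(-n4cncn4)cc3)n2)cc1`, is not yet measured. It differs from compound 2 as follows: bromo in place of chloro on an aromatic carbon. Among the measured compounds shown here, the only step that bears on this is the earlier halogen exchange on the same aromatic carbon, a number 7.5 percentage points lower from compound 1 to compound 2 (within the scatter), which was within the scatter. On that basis no step beyond the scatter is expected from compound 2 to compound 3 in this assay; the expected step is a number 0.6 percentage points higher from compound 2 to compound 3 (within the scatter). Compound 3 is therefore estimated at 29%, within a range of 16% to 42%.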

Compound 3, a percentage reported as inhibition, at one concentration (the size of the read-out at that concentration, not a potency): 32.6%
The estimate for compound 3 lay 3.6 percentage points below the measured number, within the range that was stated.
By their numbers in this assay, from the lowest: compounds 2, 3 and 1 (each within the scatter of the next).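

In this assay, bromo in place of chloro on this aromatic carbon gives a number 4.2 percentage points higher from compound 2 to compound 3 (within the scatter) and bromo in place of fluoro gives a number 3.3 percentage points lower from compound 1 to compound 3 (within the scatter). The position now carries three different halogens, and none of the printed steps among compound 1, compound 2 and compound 3 lies beyond the scatter, so the halogen exchange seen earlier as a single step now holds across the whole set of three compounds. No measurement at hand offers an explanation for these numbers.

The compounds shown carry only halogens at this position, so it stays open whether a methoxy group, an amine or a carboxylic acid there would give a step beyond the scatter. Also open, as far as these compounds go, is what a change elsewhere would do, as all three compounds share the same core.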